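Carboxy to pyridinyl carbamoyl on a shared core

A few compounds are considered here, and "the series" means these few. Any claim that something is new, unique, unknown or untested is made for them only; others in the source may bear on it.

Measured so far in an ADME assay on MRC5 cells (Homo sapiens) for inhibition, with a stated time of 72 h; on this read-out higher numbers stand for an effect only at larger amounts of compound and lower numbers for an effect already at smaller amounts:
compound 1, `COc1cccc(OC)c1C(=O)Nc1c[nH]nc1C(=O)O`, > 50000 nM
compound 2, `CO[C@H]1CC[C@H](NC(=O)c2n[nH]cc2NC(=O)c2ccc(N3CCCC3)cc2)CC1`, > 50000 nM
compound 3, `CO[C@H]1CC[C@H](NC(=O)c2n[nH]cc2NC(=O)c2ccccc2F)CC1`, compound 3 gives 1000 nM.

The value of compound 1 is a limit of this assay, not a number. The same is true of compound 2, whose value is also a limit. Compound 3 gives 1000 nM in this assay, a number rather than a limit. Compound 1 thus stands at the limit of > 50000 nM in this assay, at which 2 of the 3 values shown sit.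

Compound 4, `COc1cccc(OC)c1C(=O)Nc1c[nH]nc1C(=O)Nc1ccccn1`, is not yet measured. It differs from compound 1 in one place: (pyridin-2-yl)amino in place of hydroxy on a carbonyl carbon. For the measured compounds named here, no measured pair shows this change, so its size is unknown. For compound 4 the expected step is an at least 1.6-fold lower number from compound 1 to compound 4 (0.22 log units; that floor lies within the scatter), towards an effect at smaller amounts, though a result still at the limit remains likely. The estimate for compound 4 is 30000 nM, with a range from 5000 nM to 100000 nM.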

Compound 4, half-maximal effective concentration: > 50000 nM
Compound 4 ended at the assay's limit; the forecaster's own chance of this, stated with the estimate: 55%; middle value at least 1.6-fold (0.22 log units) away from the limit.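

In this assay compound 4 gives > 50000 nM, a limit and not a number. Compound 1 also stands at a limit, and the step between compound 1 and compound 4 cannot be read. On these data alone, whether (pyridin-2-yl)amino in place of hydroxy on a carbonyl carbon changes the read-out at all stays open.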